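Replacing a carbamate isopropoxy group with a cyclic carbonyl substituent

A few compounds are considered here, and "the series" means these few. Any claim that something is new, unique, unknown or untested is made for them only; others in the source may bear on it.

Of the compounds shown here, three have been measured in an assay on cells with Cystic fibrosis transmembrane conductance regulator variant F508del (Homo sapiens) as the target, read by voltage clamp, with a stated time of 24 h, in the presence of a further agent that is not named here; on this read-out lower numbers stand for smaller maximal responses and higher numbers for larger maximal responses. Compound 1 `COc1ccc(C(F)(F)F)cc1CO[C@H]1[C@H](C(C)(C)C)[C@@H](C(=O)O)N(C(=O)C2CCCCC2)[C@H]1c1ccccc1` gives 590%, compound 2 `COc1ncc(C2CCCC2)cc1CO[C@H]1[C@H](C(C)(C)C)[C@@H](C(=O)O)N(C(=O)C2CCCCC2)[C@H]1c1ccccc1` gives 203%, and compound 3 `COc1ncc(C(F)(F)F)cc1CO[C@H]1[C@H](C(C)(C)C)[C@@H](C(=O)O)N(C(=O)OC(C)C)[C@H]1c1ccccc1` gives 438%. Compound 3 thus stands second highest of the three: compound 1 lies above it and compound 2 lies below it, both differences beyond the scatter. Compound 4 `COc1ncc(C(F)(F)F)cc1CO[C@H]1[C@H](C(C)(C)C)[C@@H](C(=O)O)N(C(=O)[C@H]2CCCCO2)[C@H]1c1ccccc1` differs from compound 3 in one place: oxan-2-yl in place of isopropoxy on a carbonyl carbon. For the measured compounds named here, no pair of measured compounds shows this exact step. Since compound 1, which also bears a ring on that carbonyl carbon, gives 590%, compound 4 is expected to reach roughly 470% in this assay, within 300% to 650%, an expected step of a number 32 percentage points higher from compound 3 to compound 4 (beyond the scatter) that may well stay within the scatter.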

Compound 4, largest response reached (Emax), in percent of the reference or control that the assay uses: 351%
Compound 4: the middle estimate sits 119 percentage points above what was measured; the range from low to high includes it.
By their numbers in this assay, from the lowest: compound 2; then compound 4; then compound 3; then compound 1.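

In this assay this position proves sensitive to what sits on the carbonyl carbon: oxan-2-yl in place of isopropoxy gives a number 87 percentage points lower from compound 3 to compound 4 (beyond the scatter). Even so, compound 4 keeps a substantial response of 351%, so this ring is accepted here without matching the isopropoxy group. No measurement shown accounts for this step.

From the compounds shown here alone, whether the step follows from the ring oxygen, the ring itself or the defined stereocentre stays open. Cyclohexyl, the opposite oxan-2-yl stereoisomer or a dimethylamino group on this carbonyl carbon would help to separate these.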